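The source may report more compounds than this note shows. Statements on the series, on what has been measured and on what is new or still open speak of the compounds shown alone.

Measured so far:
- compound 1 `CC(C)(C)c1ccc(OC(C)(C)C2OCC(C/C=C\CCC(=O)O)C(c3cccnc3)O2)cc1` gives 1910 nM
- compound 2 `CC(C)(Oc1ccccc1[N+](=O)[O-])C1OCC(C/C=C\CCC(=O)O)C(c2cccnc2)O1` gives 11.2 nM

In a functional assay for inhibition, with Homo sapiens as the target (on this read-out lower numbers stand for tighter binding and higher numbers for weaker binding), compound 2 at 11.2 nM holds the lower number of the pair. Compound 3 `CC(C)(Cc1ccc(F)cc1C#N)C1OCC(C/C=C\CCC(=O)O)C(c2cccnc2)O1` is not yet measured and differs from compound 2 as follows: a group of 10 heavy atoms (8 carbon, 1 nitrogen, 1 fluorine; one six-membered aromatic ring of carbon only) in place of a group of 10 heavy atoms (6 carbon, 1 nitrogen, 3 oxygen; one six-membered aromatic ring of carbon only), on a saturated chain carbon bound to two saturated chain carbons and a saturated ring carbon in that place. Within the data shown here, the only measured step is a 170-fold lower number from compound 1 to compound 2 (2.23 log units; beyond the scatter) and it is large, so the range is kept wide. That step does not test the entering group. The expected move in this assay is upward and modest, estimated as a 2.7-fold higher number from compound 2 to compound 3 (0.43 log units; beyond the scatter) in size. For compound 3 the expected value is 30 nM with an estimated range from 6 nM to 150 nM for now.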

Compound 3, dissociation constant: 2.19 nM
Compound 3: the middle estimate sits 14-fold (1.14 log units) above what was measured; measured number outside the range, below it.
By their numbers in this assay, from the lowest: compound 3; then compound 2; then compound 1.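

In this assay, at the saturated chain carbon bound to two saturated chain carbons and a saturated ring carbon, 2-nitrophenoxy is not needed for a low number: the group with the nitrile and fluorine gives a 5.1-fold lower number from compound 2 to compound 3 (0.71 log units; beyond the scatter). Against the group of compound 1, the same group gives an 870-fold lower number from compound 1 to compound 3 (2.94 log units; beyond the scatter), the largest step in the series so far. No measurement on hand bears on the origin of these steps.

On these data alone, the share of the nitrile and of the fluorine in these steps remains open. So does the result of placing an amine or a longer chain on this carbon.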